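The source may report more compounds than this note shows. Statements on the series, on what has been measured and on what is new or still open speak of the compounds shown alone.

Measured in a functional assay on A549 cells (Homo sapiens) for antiproliferative activity, read by MTT assay, with a stated time of 48 h; a lower number here means a stronger inhibitor, a higher number a weaker inhibitor:
Compound 1 `Cc1ccccc1-n1nncc1CN1C(=O)C2(C(C#N)=C(N)Oc3c2c2nc4ccccc4nc2c2ccccc32)c2ccccc21`: > 50000 nM, a limit of the assay.
Compound 2 `Cc1cccc(-n2nncc2CN2C(=O)C3(C(C#N)=C(N)Oc4c3c3nc5ccccc5nc3c3ccccc43)c3ccccc32)c1`: 39600 nM.
Compound 3 `CCOc1ccc(-n2nncc2CN2C(=O)C3(C(C#N)=C(N)Oc4c3c3nc5ccccc5nc3c3ccccc43)c3ccccc32)cc1`: 25200 nM.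

Compound 3 gives the lowest of the two numbers shown; its nearest neighbour is compound 2, and the step of a 1.6-fold lower number from compound 2 to compound 3 (0.20 log units; within the scatter) stays within the scatter. The value of compound 1 is a limit only. Compound 4 `Cc1ccc(Cl)cc1-n1nncc1CN1C(=O)C2(C(C#N)=C(N)Oc3c2c2nc4ccccc4nc2c2ccccc32)c2ccccc21` differs from compound 3 by 5-chloro-2-methylphenyl in place of 4-ethoxyphenyl on an aromatic nitrogen. Within the data shown here, the steps that bear on this change are an at least 1.9-fold lower number from compound 1 to compound 3 (0.29 log units; that floor lies within the scatter), a 1.6-fold lower number from compound 2 to compound 3 (0.20 log units; within the scatter) and an at least 1.2-fold lower number from compound 1 to compound 2 (0.10 log units; that floor lies within the scatter); none reaches beyond the scatter. Compound 1, the structure closest to compound 4, sits at the limit of > 50000 nM in this assay, at which 1 of the 3 values shown sits, so compound 4 is expected to take a higher number, with a 1.6-fold higher number from compound 3 to compound 4 (0.20 log units; within the scatter). Compound 4 is estimated at 40000 nM, within 18000 nM to 90000 nM.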

Compound 4, half-maximal inhibitory concentration: > 50000 nM
Compound 4: only a limit was reported (the forecaster's own chance of this, stated with the estimate: 40%); at least 1.2-fold (0.09 log units) between middle value and limit.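

In this assay the value of compound 4 is again only a limit, so adding chloro to the 2-methylphenyl group of compound 1 brings no value into the readable range, and that step cannot be read: the limit of > 50000 nM in this assay, at which 2 of the 4 values shown sit.

Against the other aryl groups, the change gives an at least 1.9-fold higher number from compound 3 to compound 4 (0.29 log units; that floor lies within the scatter) and an at least 1.2-fold higher number from compound 2 to compound 4 (0.10 log units; that floor lies within the scatter), so 5-chloro-2-methylphenyl is not yet separated from 4-ethoxyphenyl or 3-methylphenyl.

The compounds shown leave open how an amine or a carboxylic acid on this phenyl ring would read, and whether any group at this position moves the number beyond the scatter.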